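The source may hold more compounds than are shown below. What is called first, only, known or untested is meant among the compounds shown, and "the series" means these compounds.

Working notes on the thiocarbamate series in a functional assay on SW480 cells (Homo sapiens) for antiproliferative activity, read by MTT assay, with a stated time of 72 h; a higher number here means a weaker inhibitor, a lower number a stronger inhibitor.

The compounds share a chromone-derived core bearing a dithiocarbamate arm; compound 1 `O=c1c(SC(=S)N2CCCC2)coc2ccc(Cl)cc12` carries the arm directly on the core, while compound 2 `COc1ccc2oc(CSC(=S)N3CCOCC3)cc(=O)c2c1` and compound 3 `O=c1cc(CSC(=S)N2CCCC2)oc2ccccc12` carry it through a methylene. In this assay compound 1 is reported only as a limit, > 25000 nM, and that limit is the one described by the limit of > 25000 nM in this assay, at which 1 of the 3 values shown sits. Compound 2 gives 3100 nM, the lowest of the two numbers obtained, and compound 3 gives 23400 nM, a gap that lies beyond the scatter of this assay. Compound 2 and compound 3 differ at more than one place, so that gap is not assigned to any single change.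

Compound 4 `COc1ccc2oc(CSC(=S)N(C(C)C)C(C)C)cc(=O)c2c1` is the next member, not yet measured in this assay. It keeps the core of compound 2 and differs only at the arm: diisopropylamino in place of morpholin-4-yl on a thiocarbonyl carbon. Within the data shown here, no measured pair in the set isolates a change of this kind, so the expected step is drawn from the scatter alone. The expected step from compound 2 to compound 4 is a 1.3-fold higher number from compound 2 to compound 4 (0.11 log units; within the scatter), with no direction beyond the scatter asserted. Compound 4 is therefore estimated at 4000 nM, in the range 1500 nM to 12000 nM.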

Compound 4, half-maximal inhibitory concentration: 7200 nM
Compound 4: middle estimate off by 1.8-fold (0.26 log units), on the low side; low and high end bracket the measured number.
By their numbers in this assay, from the lowest: compound 2; then compound 4; then compound 3. At a limit, above all of these: compound 1.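

With the core of compound 2 held fixed, the arm gives the series its first readable single-place step in this assay: diisopropylamino in place of morpholin-4-yl on a thiocarbonyl carbon gives a 2.3-fold higher number from compound 2 to compound 4 (0.37 log units; beyond the scatter), modest in size but beyond the scatter. With the ring and its oxygen both gone, compound 4 gives 7200 nM. Nothing measured here accounts for this step.

A single step cannot separate the loss of the ring from the loss of the ring oxygen, and piperidin-1-yl or dimethylamino on the same thiocarbonyl carbon would pull these two apart. On these data alone, the step also rests on one core, so whether it holds on the core of compound 3 remains open.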